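Methoxy in Place of Methyl on a Shared Core

This account rests on a few compounds, and the source may have more. Where it says the series, first, only, none or still open, it means among the compounds named here.

Of the compounds shown here, three built on one shared core have been tested in a functional assay on HEK293 cells for agonist activity at Glucose-dependent insulinotropic receptor (Homo sapiens), read by fluorescence and cAMP accumulation, with a stated time of 30 min; on this read-out higher numbers stand for an effect only at larger amounts of compound and lower numbers for an effect already at smaller amounts. Compound 1 `Cc1c(Nc2ccc(C#N)cc2Cl)ncnc1OC1C2COCC1CN(S(=O)(=O)C1CC1)C2` carries a methyl on the core together with a cyclopropylsulfonyl group on the bicyclic amine; in this assay compound 1 gives 51 nM; 1210 nM (2 entries), and the two entries lie far apart, as the several entries of compound 1 in this assay, 51 nM; 1210 nM (2 entries) shows. Compound 2 `COc1c(Nc2ccc(C#N)cc2F)ncnc1OC1C2COCC1CN(C(=O)OC1(C)CC1)C2` carries a methoxy and a carbamate instead of the sulfonyl group, and in this assay compound 2 gives 5 nM. Compound 3 `Cc1c(Nc2ccc(C#N)cc2Cl)ncnc1OC1C2COCC1CN(C(=O)OC1(C)CC1)C2` keeps the methyl of compound 1 but the carbamate of compound 2; in this assay compound 3 gives 4 nM, the lowest single number shown, though its gap to compound 2 is within the scatter, so the two count as alike.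

Compound 4 `COc1c(Nc2ccc(C#N)cc2Cl)ncnc1OC1C2COCC1CN(C(=O)OC1(C)CC1)C2` has not yet been measured. It differs from compound 3 by methoxy in place of methyl on an aromatic carbon. Among the compounds with values here, no measured pair differs only in this place, so the step is a judgement. Since compound 2 already holds a methoxy on the core and gives 5 nM, the step is expected to be small, and the expected step of a 1.1-fold higher number from compound 3 to compound 4 (0.05 log units; within the scatter) stays within the scatter. Compound 4 is therefore estimated to give 4.5 nM, with a range from 1.5 nM to 14 nM.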

Compound 4, half-maximal effective concentration in the Glucose-dependent insulinotropic receptor assay: 7 nM
Compound 4: the middle estimate sits 1.6-fold (0.19 log units) below what was measured; measured number inside the range.
By their numbers in the Glucose-dependent insulinotropic receptor assay, from the lowest: compounds 3, 2 and 4 (each within the scatter of the next).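

In the Glucose-dependent insulinotropic receptor assay, the swap on the aromatic carbon ortho to a (2-chloro-4-cyanophenyl)amino group can now be read directly, as a 1.8-fold higher number from compound 3 to compound 4 (0.24 log units; within the scatter), and chloro in place of fluoro elsewhere on the molecule gives a 1.4-fold higher number from compound 2 to compound 4 (0.15 log units; within the scatter), so neither change separates the compounds on this read-out. The swap does separate them in a physicochemical assay for solubility, at pH 7.4 (a lower number here means a less soluble compound, a higher number a more soluble compound), where compound 3 gives 6000 nM and compound 4 gives 30000 nM. On this one pair, then, methoxy in place of methyl at this position raises solubility while the receptor number stays within the scatter: the measured solubility of compound 3, 6000 nM, and of compound 4, 30000 nM, a 5.0-fold higher number (0.70 log units; beyond the scatter).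

The compounds shown hold only methyl and methoxy at this position, so it remains open whether an ethoxy or a dimethylamino group there would keep the receptor number and what either would do to solubility. It also remains open whether the same swap would behave alike with the cyclopropylsulfonyl group of compound 1 in place of the carbamate, and the widely separated entries of compound 1 would make any such comparison hard to read: the several entries of compound 1 in the Glucose-dependent insulinotropic receptor assay, 51 nM; 1210 nM (2 entries)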